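Aryl amide variation on a shared core: growth inhibition notes

The source may hold more compounds than are shown below. What is called first, only, known or untested is meant among the compounds shown, and "the series" means these compounds.

Measured so far:
compound 1 `COc1ccc(NC(=O)C2(C(=O)Nc3ccc(Nc4ncc5cc(C(=O)N(C)C)n(C6CCCC6)c5n4)cc3)CC2)cc1` gives 76.4%
compound 2 `CN(C)C(=O)c1cc2cnc(Nc3ccc(NC(=O)C4(C(=O)Nc5ccccc5F)CC4)cc3)nc2n1C1CCCC1` gives 85.2%
compound 3 `CN(C)C(=O)c1cc2cnc(Nc3ccc(NC(=O)C4(C(=O)Nc5cccc(Cl)c5)CC4)cc3)nc2n1C1CCCC1` gives 39.3%

In a functional assay on T47D cells (Homo sapiens) for inhibition, read by CCK-8 assay, with a stated time of 72 h, tested at 1 uM (a higher number here means more inhibition of growth at the concentration tested, a lower number less inhibition of growth), compound 3 stands lowest of the three numbers; the other two are each well above it, as a number 37.1 percentage points lower from compound 1 to compound 3 (beyond the scatter) and a number 45.9 percentage points lower from compound 2 to compound 3 (beyond the scatter) show, while a number 8.8 percentage points higher from compound 1 to compound 2 (within the scatter) does not separate compound 1 from compound 2.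

Compound 4 `CN(C)C(=O)c1cc2cnc(Nc3ccc(NC(=O)C4(C(=O)Nc5ccccc5)CC4)cc3)nc2n1C1CCCC1` is not yet measured. It differs from compound 3 by hydrogen in place of chloro on an aromatic carbon. Going by the values given here, the change removes the one group that sets compound 3 apart from compound 1 and compound 2, and both steps onto compound 3 were large and downward. Among the compounds with values here, the bearing steps therefore point to a large upward step for compound 4, back toward the numbers of compound 1 and compound 2, though no measured step covers a plain phenyl group itself, so the size is uncertain. The expected step is a number 30.7 percentage points higher from compound 3 to compound 4 (beyond the scatter). In this assay compound 4 is estimated at 70%, with a range from 45% to 90%.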

Compound 4, percent growth inhibition at one concentration: 52.8%
For compound 4 the middle estimate is 17.2 percentage points above the measured one; measured number inside the range.
By their numbers in this assay, from the lowest: compound 3; then compound 4; then compounds 1 and 2 (each within the scatter of the next).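

Removing the chloro lifts growth inhibition in this assay only part of the way, a number 13.5 percentage points higher from compound 3 to compound 4 (beyond the scatter), so the low number of compound 3 is not the whole gap within this group of compounds. The plain phenyl does not serve as a neutral match for the other two aryl groups: a number 32.4 percentage points lower from compound 2 to compound 4 (beyond the scatter) and a number 23.6 percentage points lower from compound 1 to compound 4 (beyond the scatter), so 2-fluorophenyl and 4-methoxyphenyl both read above phenyl, while 3-chlorophenyl, in compound 3, goes against that direction and reads below it. Nothing available explains these steps.

Compound 2 and compound 3 differ in both the halogen and its place on the ring, so the two contributions remain unseparated. As far as these compounds go, how an amine or a carboxylic acid on this phenyl ring would read in this assay also stays open.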